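This account rests on a few compounds, and the source may have more. Where it says the series, first, only, none or still open, it means among the compounds named here.

Compound 1 `Cc1cc(NCc2ccc(F)cc2)c2ccccc2n1` gives 20100 nM in a functional assay on MCF-10A cells (Homo sapiens) for antiproliferative activity, with a stated time of 48 h; a higher number here means that more compound is needed for the effect, a lower number that less compound is needed. Compound 2 `CCCOc1ccc2nc(C)cc(NCc3ccc(F)cc3)c2c1` gives 14300 nM in this assay, and compound 3 `CCCCCCOc1ccc2nc(C)cc(NCc3ccc(F)cc3)c2c1` gives 9100 nM. Compound 3 holds the lowest of the three numbers: its gap to compound 2 is within the scatter, whereas the step of a 2.2-fold lower number from compound 1 to compound 3 (0.34 log units; beyond the scatter) is beyond it. Compound 4 `CCCCCCCCOc1ccc2nc(C)cc(NCc3ccc(F)cc3)c2c1` differs from compound 3 by ethyl in place of hydrogen on a saturated chain carbon, six bonds along the chain from an oxygen on an aromatic ring. The step that bears most directly on this change is a 1.6-fold lower number from compound 2 to compound 3 (0.20 log units; within the scatter), a lengthening of the same chain; the steps of a 1.4-fold lower number from compound 1 to compound 2 (0.15 log units; within the scatter) and a 2.2-fold lower number from compound 1 to compound 3 (0.34 log units; beyond the scatter) point in the same direction, though only the latter is beyond the scatter. For the measured compounds named here, no step so far has moved the number by more than a modest amount. A further small lowering is therefore expected for compound 4, estimated as a 1.3-fold lower number from compound 3 to compound 4 (0.13 log units; within the scatter), most likely within the scatter. Compound 4 is expected to give 6800 nM, with a range from 3500 nM to 13000 nM.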

Compound 4, half-maximal effective concentration: 2200 nM
Compound 4: middle estimate off by 3.1-fold (0.49 log units), on the high side; measured number outside the range, below it.
By their numbers in this assay, from the lowest: compound 4; then compounds 3, 2 and 1 (each within the scatter of the next, the first and the last beyond it).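

Along the alkoxy chain, ethyl in place of hydrogen, six bonds along the chain from an oxygen on an aromatic ring, gives a 4.1-fold lower number from compound 3 to compound 4 (0.62 log units; beyond the scatter) in this assay and is thus a step beyond the scatter, whereas a 1.6-fold lower number from compound 2 to compound 3 (0.20 log units; within the scatter) stayed within it. The longer comparisons, a 6.5-fold lower number from compound 2 to compound 4 (0.81 log units; beyond the scatter) for pentyl at the chain carbon three bonds along and a 9.1-fold lower number from compound 1 to compound 4 (0.96 log units; beyond the scatter) for octyloxy on the aromatic carbon, are the largest in the series, so this position still responds to chain length at octyloxy, and the response is not even from one chain to the next. No measurement shown accounts for the size of this last step.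

From the compounds shown here alone, whether a longer chain, such as decyloxy, lowers the number further remains open. So does whether an amine or a carboxylic acid at the end of the octyl chain would retain the lower number of compound 4.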